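The compounds below may be only part of what the source reports. "The series", "measured", "known", "first", "only" and "open" are said of these compounds alone.

Measured in a functional assay on HT-29 cells (Homo sapiens) for cytotoxicity, read by MTT assay, with a stated time of 3 days; a lower number here means a stronger inhibitor, a higher number a weaker inhibitor:
- Compound 1 `COc1cccc(-c2cccc(O)c2)c1`: 16 ug/mL
- Compound 2 `COc1ccc(-c2ccccc2)cc1`: 45 ug/mL

Of these two, compound 2 gives the higher number, 45 ug/mL, making it the weaker inhibitor, while compound 1 gives 16 ug/mL. The gap between them lies beyond the usual scatter.

The next compound to be tested is compound 3 `COc1ccc(-c2cccc(O)c2)cc1`. It differs from compound 2 by one change, hydroxy in place of hydrogen on an aromatic carbon. Among the measured compounds shown here, no measured pair shows this change on its own, so its effect in this assay cannot be read directly from the data. For the measured compounds named here, the only guide is compound 1, which also carries a hydroxy group and gives 16 ug/mL, although it differs from compound 3 in the arrangement of its groups. A moderate fall in the number is therefore expected, just beyond the scatter, with a real chance of no clear change. The expected step is a 2.3-fold lower number from compound 2 to compound 3 (0.35 log units; beyond the scatter). For compound 3 the estimated value is 20 ug/mL, with an expected range from 9 ug/mL to 45 ug/mL.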

Compound 3, half-maximal inhibitory concentration: 72 ug/mL
Compound 3: the middle estimate sits 3.6-fold (0.56 log units) below what was measured; measured number outside the range, above it.
By their numbers in this assay, from the lowest: compound 1; then compounds 2 and 3 (each within the scatter of the next).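

In this assay, placing a hydroxy group in place of hydrogen on an aromatic carbon, meta to a group of 8 heavy atoms, gives a 1.6-fold higher number from compound 2 to compound 3 (0.20 log units; within the scatter). Among the compounds shown here, this is the first reading of the change on its own, and it shows that at this position the hydroxy group brings no difference that can be told from the scatter, so the number of the hydroxy-bearing compound 1 does not carry over to this place. Nothing measured here bears on why the change behaves this way at this position.

The compounds shown leave open whether an amine or a carboxylic acid on the same aromatic carbon would move the number beyond the scatter, or whether it would stay as close to compound 2 as the hydroxy group does. They also leave open what the hydroxy group contributes in compound 1, at 16 ug/mL, as no compound among those shown matches compound 1 with hydrogen in place of its hydroxy group.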